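Trifluoromethyl in place of chloro: compound 3 awaits its number

This account rests on a few compounds, and the source may have more. Where it says the series, first, only, none or still open, it means among the compounds named here.

Two close relatives have been measured so far in a functional assay on SW-620 cells (Homo sapiens) for inhibition, read by MTT assay, with a stated time of 72 h; a higher number here means a weaker inhibitor, a lower number a stronger inhibitor. Compound 1 `COc1cc(NC(C)CCCNC(=O)NNC(=O)Nc2ccc(F)cc2)c2ncccc2c1` is recorded only as a limit of the assay, > 100000 nM. Among the measured compounds shown here, compound 2 `COc1cc(NC(C)CCCNC(=O)NNC(=O)Nc2ccc(Cl)cc2)c2ncccc2c1` gives 48000 nM, which is the only true number available, so it has no measured neighbour to be ranked against.

The next compound, compound 3 `COc1cc(NC(C)CCCNC(=O)NNC(=O)Nc2ccc(C(F)(F)F)cc2)c2ncccc2c1`, has trifluoromethyl in place of chloro on an aromatic carbon, para to a large group (trifluoromethyl in place of chloro on an aromatic carbon). For the measured compounds named here, one measured step bears on this site, chloro in place of fluoro, which gave an at least 2.0-fold lower number from compound 1 to compound 2 (0.31 log units; beyond the scatter). As far as these compounds go, that step has a limit at one end, so its true size remains open, and it involves a different pair of groups. It shows that this assay can respond to a change at this site, but it does not fix a direction for the new change. Starting from compound 2 at 48000 nM, no shift beyond the scatter is the likeliest outcome, although a modest one either way is possible. The expected change is a 1.1-fold lower number from compound 2 to compound 3 (0.06 log units; within the scatter). For compound 3 the estimated value is 42000 nM, with an expected range of 15000 nM to 100000 nM.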

Compound 3, half-maximal inhibitory concentration: 12000 nM
Beside the measured number, compound 3's estimate is 3.5-fold (0.54 log units) above it; measured number below the stated range.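

In this assay, this site, on an aromatic carbon para to a large group, now has a step between two true numbers: there is a 4.0-fold lower number from compound 2 to compound 3 (0.60 log units; beyond the scatter), so trifluoromethyl in place of chloro has a size that the earlier pair, with a limit at one end, could not give. Across the three compounds, the number falls from fluoro to chloro to trifluoromethyl, and the whole span is an at least 8.3-fold lower number from compound 1 to compound 3 (0.92 log units; beyond the scatter). Compound 1 is recorded only as a limit, so the steps that start from it fix only the smallest size they can have: the limit of > 100000 nM in this assay, at which 1 of the 3 values shown sits.

The compounds shown leave open whether this order holds for other groups at the same site, such as a nitrile, a methoxy or a tert-butyl, and whether trifluoromethyl would give a similar number elsewhere on the same ring. They also leave open how far the number depends on the rest of the molecule, since the shared core and its chain stay the same throughout, and a longer chain or an added amine there remains an untested question in this account.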